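Arylidene oxindoles: swapping nitro for chloro on the pendant ring

A few compounds are considered here, and "the series" means these few. Any claim that something is new, unique, unknown or untested is made for them only; others in the source may bear on it.

Measured so far in a functional assay on KB cells (Homo sapiens) for cytotoxicity, read by MTT assay, with a stated time of 72 h; on this read-out lower numbers stand for an effect already at smaller amounts and higher numbers for an effect only at larger amounts of compound:
compound 1 `CN(C)c1ccc(/C=C2\C(=O)N(c3c(Cl)cccc3Cl)c3ccccc32)cc1` — 15 ug/mL
compound 2 `COc1ccc(/C=C2\C(=O)N(c3c(Cl)cccc3Cl)c3ccccc32)cc1` — > 100 ug/mL
compound 3 `O=C1/C(=C\c2ccccc2[N+](=O)[O-])c2ccccc2N1c1c(Cl)cccc1Cl` — 1 ug/mL

In this assay compound 2 gives only a limit, > 100 ug/mL, not a number. Compound 3 stands at the lowest of the two numbers shown; compound 1 is nearest, with a 15-fold lower number from compound 1 to compound 3 (1.18 log units; beyond the scatter) separating them. The steps of a 15-fold lower number from compound 1 to compound 3 (1.18 log units; beyond the scatter) and an at least 100-fold lower number from compound 2 to compound 3 (2.00 log units; beyond the scatter) both turn on the aryl group on the double-bonded chain carbon, and both point to 2-nitrophenyl as the variant with the lowest number. The step of an at least 6.6-fold higher number from compound 1 to compound 2 (0.82 log units; beyond the scatter) concerns a change of substituent on that same ring.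

Compound 4 `O=C1/C(=C\c2ccccc2Cl)c2ccccc2N1c1c(Cl)cccc1Cl` keeps the core of compound 3 and differs only by chloro in place of nitro on an aromatic carbon. For the measured compounds named here, no measured step covers this exact change; the nearest evidence is that both replacements of 2-nitrophenyl in hand gave large shifts, though in those cases the whole aryl group changed. A modest upward movement in this assay is expected for compound 4, a 5.0-fold higher number from compound 3 to compound 4 (0.70 log units; beyond the scatter). Compound 4 is estimated at 5 ug/mL, with a range from 1.5 ug/mL to 20 ug/mL.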

Compound 4, concentration for half-maximal effect: 5 ug/mL
The estimate for compound 4 equals the measured number at the digits printed, within the range that was stated.
By their numbers in this assay, from the lowest: compound 3; then compound 4; then compound 1. At a limit, above all of these: compound 2.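

In this assay, for the compounds shown here, exchanging nitro for chloro while the rest of compound 3 stays unchanged gives a 5.0-fold higher number from compound 3 to compound 4 (0.70 log units; beyond the scatter): the number rises, but only modestly, so nitro is not the sole group at this place, ortho to a large group, that goes with a low number. The 2-chlorophenyl group also compares favourably with 4-(dimethylamino)phenyl, with a 3.0-fold lower number from compound 1 to compound 4 (0.48 log units; beyond the scatter). The comparison with 4-methoxyphenyl gives an at least 20-fold lower number from compound 2 to compound 4 (1.30 log units; beyond the scatter), but this step is only a bound, as compound 2 gives a limit and not a number: the limit of > 100 ug/mL in this assay, at which 1 of the 4 values shown sits.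

Still open, on these data alone, is what an amine or a carboxylic acid at this same place would give. Also open, as far as these compounds go, is how the 2-nitrophenyl and 2-chlorophenyl compounds compare with a plain phenyl group on the same core.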